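This account rests on a few compounds, and the source may have more. Where it says the series, first, only, none or still open, it means among the compounds named here.

Values in a functional assay on HepG2 cells (Homo sapiens) for inhibition, read by MTT assay, with a stated time of 48 h; a lower number here means a stronger inhibitor, a higher number a weaker inhibitor:
- compound 1 `CCSc1nnc(-c2cc(OC)c(OC)c(OC)c2)n1-c1ccc(OC)cc1`: > 60000 nM
- compound 2 `COc1ccc(-n2c(SCC(=O)C3CC3)nnc2-c2cc(OC)c(OC)c(OC)c2)cc1`: > 60000 nM
- compound 3 `CCSc1nnc(-c2cc(OC)c(OC)c(OC)c2)n1-c1ccc(N(C)C)cc1`: > 60000 nM

Each entry is a limit and not a number. Compound 3 gives > 60000 nM, a limit. Among the measured compounds shown here, the series so far reads as the limit of > 60000 nM in this assay, at which 3 of the 3 values shown sit.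

Compound 4 `COc1cc(-c2nnc(SCc3ccc(F)cc3)n2-c2ccc(N(C)C)cc2)cc(OC)c1OC` carries 4-fluorophenyl in place of methyl on a saturated chain carbon bound to a sulfur.

The step at the same place, a step that the two limits leave unreadable from compound 1 to compound 2, has no readable size, and neither has a step that the two limits leave unreadable from compound 1 to compound 3. Neither gives a size or direction to carry over, so the estimate is loose. A numerical result in this assay could only lie on the stronger side of the limit. The expected step is an at least 2.0-fold lower number from compound 3 to compound 4 (0.30 log units; that floor lies within the scatter). Compound 4 is estimated at 30000 nM, with an expected range of 5000 nM to 60000 nM.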

Compound 4, half-maximal inhibitory concentration: 26400 nM
Compound 4: the middle estimate sits 1.1-fold (0.06 log units) above what was measured; the measured number falls inside the stated range.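

In this assay, 4-fluorophenyl in place of methyl on a saturated chain carbon bound to a sulfur gives an at least 2.2-fold lower number from compound 3 to compound 4 (0.35 log units; beyond the scatter). Among the compounds shown here, this is the first readable change at this position, and its size is only a floor, as the value of compound 3 is a limit. The earlier steps from compound 1 cannot be read, and compound 4 alone comes off the limit: the limit of > 60000 nM in this assay, at which 3 of the 4 values shown sit.

Open, on these data alone, is whether 4-fluorobenzyl would do the same alongside the methoxy of compound 1. Also open, as far as these compounds go, is whether unsubstituted benzyl, a longer chain or a carboxylic acid at this place would give a numerical value.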